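The source may hold more compounds than are shown below. What is called first, only, known or untested is meant among the compounds shown, and "the series" means these compounds.

Measured so far:
compound 1, `C(=C/c1ccccc1)\CN1CCC(CCOC(c2ccccc2)c2ccccc2)CC1`: 10.1 nM
compound 2, `Fc1ccc(/C=C/CN2CCC(CCOC(c3ccccc3)c3ccccc3)CC2)cc1`: 10.8 nM

In an assay on cell membranes from brain for inhibition of sodium-dependent dopamine transporter (Rattus norvegicus) (a lower number here means a stronger inhibitor, a higher number a weaker inhibitor), compound 1 gives 10.1 nM, and in the same assay compound 2 gives 10.8 nM. Going by the values given here, on these numbers compound 2 cannot be set apart from compound 1, since the single measured step, a 1.1-fold higher number from compound 1 to compound 2 (0.03 log units; within the scatter), falls inside the scatter of repeat measurements; compound 2 therefore stands level with its only neighbour.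

Compound 3, `C(=C/c1cccs1)\CN1CCC(CCOC(c2ccccc2)c2ccccc2)CC1`, differs from compound 2 in one place: thiophen-2-yl in place of 4-fluorophenyl on a double-bonded chain carbon bound to a double-bonded chain carbon. Among the compounds with values here, the one step measured, a 1.1-fold higher number from compound 1 to compound 2 (0.03 log units; within the scatter), concerned a fluoro in place of hydrogen on an aromatic carbon of that same ring and left the number essentially unchanged; it does not speak to swapping the six-membered ring for a five-membered ring with one hetero atom. Within the data shown here, with no direct precedent, the expectation for compound 3 is a step of a 1.1-fold higher number from compound 2 to compound 3 (0.05 log units; within the scatter) that stays close to the scatter. The estimate for compound 3 is 12 nM, with a range from 5 nM to 30 nM.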

Compound 3, half-maximal inhibitory concentration: 9.8 nM
Compound 3: the middle estimate sits 1.2-fold (0.09 log units) above what was measured; low and high end bracket the measured number.
By their numbers in this assay, from the lowest: compounds 3, 1 and 2 (each within the scatter of the next).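

In this assay, the step for thiophen-2-yl in place of 4-fluorophenyl on a double-bonded chain carbon bound to a double-bonded chain carbon is a 1.1-fold lower number from compound 2 to compound 3 (0.04 log units; within the scatter), and the step for thiophen-2-yl in place of phenyl at the same place is a 1.0-fold lower number from compound 1 to compound 3 (0.01 log units; within the scatter). The earlier step spoke only to a fluoro on an intact ring, whereas these two show that, across the three compounds, the whole ring can be exchanged here, a six-membered aromatic ring of carbon only giving way to a five-membered aromatic ring with 1 hetero atom, without the number moving beyond the scatter. Nothing further is available to account for this level behaviour.

The compounds shown leave open whether thiophen-3-yl, a pyridine ring or a saturated cyclohexyl ring would hold the number at this level, or whether a ring carrying an amine or a carboxylic acid would shift it. They also leave open whether the same tolerance would survive with a saturated propyl chain in place of the prop-2-en-1-yl link.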